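The compounds below may be only part of what the source reports. "The series", "measured", "known", "first", "only" and "open" are said of these compounds alone.

Measured compounds:
- compound 1, `COc1ccc(/C=C2\SC(=O)N(Cc3ccc(C)cc3)C2=O)c(OC)c1` — 34.6%
- compound 2, `Cc1ccc(CN2C(=O)S/C(=C\c3ccc(N(C)C)cc3)C2=O)cc1` — 40.8%

Two compounds of the series have been run in a functional assay on the whole organism (plasma) with Mus musculus as the target, with a stated time of 15 days, at a dose of 30 mg/kg by the oral route; a higher number here means a stronger effect of the compound at the dose given, a lower number a weaker effect. Compound 1 gives 34.6% in this assay. Compound 2 gives 40.8%. For the measured compounds named here, the two numbers sit within the usual scatter of each other, so compound 2 and compound 1 cannot be told apart on this read-out; compound 2 stands level with the only other measured member of the series rather than apart from it.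

Compound 3, `COc1ccc(/C=C2\SC(=O)N(Cc3ccc(C)cc3)C2=O)cc1`, has not yet been measured in this assay. The change from compound 2 to compound 3 is methoxy in place of dimethylamino on an aromatic carbon. Going by the values given here, no step between measured compounds that differ in one place is available, so nothing in the data shows how a single exchange of this kind moves the read-out. The two measured compounds, with different substitution on the same aromatic ring, stay within the scatter of each other, which gives no reason to expect a step beyond the scatter in either direction.

The expected step of a number 4.8 percentage points lower from compound 2 to compound 3 (within the scatter) is therefore small and not distinguishable from the scatter. Compound 3 is estimated at 36% in this assay, with a range from 22% to 50%.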

Compound 3, a percentage reported as activity, at one dose (the size of the read-out at that dose, not a potency): 50.8%
Beside the measured number, compound 3's estimate is 14.8 percentage points below it; measured number above the stated range.
By their numbers in this assay, from the lowest: compounds 1, 2 and 3 (each within the scatter of the next, the first and the last beyond it).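

In this assay the exchange of methoxy for dimethylamino on an aromatic carbon, para to a large group, gives a number 10 percentage points higher from compound 2 to compound 3 (within the scatter) and so leaves the two groups indistinguishable at this position on this read-out. Hydrogen in place of methoxy on an aromatic carbon gives a number 16.2 percentage points higher from compound 1 to compound 3 (beyond the scatter) and is the first single exchange in the series to clear the scatter, though the step is modest, so substitution on this ring can move the read-out at the dose given. No supporting measurement bears on why either step has its size.

The compounds shown carry only methoxy, dimethylamino and hydrogen on this ring, so the effect of a carboxylic acid, a primary amine or a fluorine there remains open. From the compounds shown here alone, all three also share the methyl on the other aromatic ring, so whether a longer chain or a chlorine in its place would change the read-out is equally open.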